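Fluoro-to-hydrogen step on the fused core, cytotoxicity series

The source may report more compounds than this note shows. Statements on the series, on what has been measured and on what is new or still open speak of the compounds shown alone.

Three compounds have been run in a functional assay on HCT-116 cells (Homo sapiens) for cytotoxicity, read by MTT assay, with a stated time of 2 days, tested at 10 uM; a higher number here means more inhibition at the concentration tested (going by the name of the read-out), a lower number less inhibition. Compound 1 `Cc1cccc(N2CCN(CCCNc3nc(NCc4ccco4)c4ccccc4n3)CC2)c1C` gives 93.2%. Compound 3 `Cc1cccc(N2CCN(CCCNc3nc(NCc4ccco4)c4cc(F)ccc4n3)CC2)c1C` gives 97.3%, and compound 2 `Fc1ccc2nc(NCCCCN3CCN(c4cccc(Cl)c4Cl)CC3)nc(NCc3ccco3)c2c1` gives 97.1%. Compound 2 and compound 3 share the same change relative to their partners, but the difference between the two cores is not broken down here; their values in this assay lie within the scatter of each other.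

The change from compound 3 to compound 1 is hydrogen in place of fluoro on an aromatic carbon. It made a step of a number 4.1 percentage points lower from compound 3 to compound 1 (within the scatter).

Compound 4 `Clc1cccc(N2CCN(CCCCNc3nc(NCc4ccco4)c4ccccc4n3)CC2)c1Cl` has not yet been measured. From compound 2 it differs by hydrogen in place of fluoro on an aromatic carbon, the same change at the same place. Because the earlier step of a number 4.1 percentage points lower from compound 3 to compound 1 (within the scatter) stayed within the scatter, the step from compound 2 to compound 4 is expected to be small as well, about a number 2.6 percentage points lower from compound 2 to compound 4 (within the scatter) in this assay. Compound 4 is therefore estimated at 94.5% in this assay, with a range from 87% to 99%.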

Compound 4, a percentage reported as inhibition, at one concentration (the size of the read-out at that concentration, not a potency): 94.7%
The estimate for compound 4 lay 0.2 percentage points below the measured number; measured number inside the range.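

In this assay, hydrogen in place of fluoro on the aromatic carbon gives a number 2.4 percentage points lower from compound 2 to compound 4 (within the scatter), and this step agrees with the earlier one on the other core: the same change on two cores in this assay, a number 4.1 percentage points lower (within the scatter) from compound 3 to compound 1 and a number 2.4 percentage points lower (within the scatter) from compound 2 to compound 4, 1.7 percentage points apart, within the scatter of two such steps.
Within these two cores, then, the exchange carries over with no step that can be told from the usual scatter, and fluoro and hydrogen at this place cannot be separated by this read-out. This does not show that the two groups are equivalent in general: the evidence is two pairs, and a reading at a single concentration gives the size of the inhibition and not a potency.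

The compounds shown leave open whether a larger group on the same aromatic carbon, such as methoxy or a nitrile, would give a step beyond the scatter. Within the data shown here, they also leave the linking chain and the substituents on the outer aromatic ring unresolved, since no pair here differs in only one of those places.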